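Replacing One Ring in a Growth Inhibitor

The source may hold more compounds than are shown below. What is called first, only, known or untested is meant among the compounds shown, and "the series" means these compounds.

For the measured compounds named here, in a functional assay on DU-145 cells (Homo sapiens) for inhibition, read by trypan blue exclusion, with a stated time of 96 h (a lower number here means a stronger inhibitor of growth, a higher number a weaker inhibitor of growth), compound 2 (`O=C(/C(=C\c1ccc(Cl)cc1)SCc1ccc(F)cc1)c1ccc(Cl)cc1`) gives 10000 nM, the lower of the two numbers so far, and compound 1 (`Cc1ccsc1/C=C(/SCc1ccc(Cl)cc1)C(=O)c1ccc(Cl)cc1`) gives 50000 nM, a gap beyond the usual scatter. Compound 3 (`Cc1ccsc1/C=C(/SCc1ccc(F)cc1)C(=O)c1ccc(Cl)cc1`) has 3-methylthiophen-2-yl in place of the 4-chlorophenyl of compound 2, on a double-bonded chain carbon bound to a double-bonded chain carbon: 3-methylthiophen-2-yl in place of 4-chlorophenyl on a double-bonded chain carbon bound to a double-bonded chain carbon. Compound 1 also carries 3-methylthiophen-2-yl, and its value in this assay is the higher one, so somewhat weaker inhibition is expected. The estimated step is a 2.5-fold higher number from compound 2 to compound 3 (0.40 log units; beyond the scatter). For compound 3, the expected value is 25000 nM, with an estimated range of 7000 nM to 80000 nM.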

Compound 3, concentration for 50% growth inhibition: 50000 nM
Estimate against measurement, compound 3: 2.0-fold (0.30 log units) below; the range from low to high includes it.
By their numbers in this assay, from the lowest: compound 2; then compounds 1 and 3 (each within the scatter of the next).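

In this assay, the direct swap of 3-methylthiophen-2-yl for 4-chlorophenyl on a double-bonded chain carbon bound to a double-bonded chain carbon gives a 5.0-fold higher number from compound 2 to compound 3 (0.70 log units; beyond the scatter) and so shows that the ring at this position matters. With 3-methylthiophen-2-yl in place, fluoro in place of chloro on an aromatic carbon gives no change at the digits printed from compound 1 to compound 3 (within the scatter) and leaves the number unmoved. No measurement shown explains either result.

Still open, from the compounds shown here alone, is how a ring carrying an amine or a carboxylic acid would behave at this position. The compounds shown also leave open whether fluoro and chloro would match with 4-chlorophenyl in place.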